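The source may report more compounds than this note shows. Statements on the series, on what has been measured and on what is new or still open speak of the compounds shown alone.

Working notes on the series. Of the compounds shown here, two have been measured so far, compound 1 (`Cc1c2c(n3c1CCCN(C)[C@@H](C)[C@H](C)Nc1cc-3ccc1C(N)=O)CC(C)(C)CC2=O`) and compound 2 (`CC(=O)N1CCc2c(C)c3c(n2-c2ccc(C(N)=O)c(c2)N[C@@H](C)[C@H](C)C1)CC(C)(C)CC3=O`). In a functional assay on U-87MG ATCC cells (Homo sapiens) for antiproliferative activity (on this read-out higher numbers stand for weaker inhibition and lower numbers for stronger inhibition), compound 1 gives 133 nM, the higher of the two numbers, and compound 2 gives 24 nM, a gap beyond the usual scatter.

Next comes compound 3 (`Cc1c2c(n3c1CCCN(C(=O)CN)[C@@H](C)[C@H](C)Nc1cc-3ccc1C(N)=O)CC(C)(C)CC2=O`), which keeps the core of compound 1 and changes one place: (aminomethyl)carbonyl in place of methyl on an amine nitrogen in a ring. This puts (aminomethyl)carbonyl in place of methyl on an amine nitrogen in a ring. Among the compounds with values here, no measured pair isolates this change, since compound 2 differs from compound 1 in more than one place. Within the data shown here, the only hint is that compound 2 also carries a carbonyl group on an amine nitrogen in a ring and stands at 24 nM. That is weak support, so a moderate move to a lower number in this assay is expected, and a result within the scatter of compound 1 is not excluded. The expected step is a 2.7-fold lower number from compound 1 to compound 3 (0.42 log units; beyond the scatter). In this assay the estimated value for compound 3 is 50 nM, with an expected range of 15 nM to 160 nM.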

Compound 3, half-maximal inhibitory concentration: 481 nM
Compound 3: middle estimate off by 9.6-fold (0.98 log units), on the low side; the whole stated range lies below it.
By their numbers in this assay, from the lowest: compound 2; then compound 1; then compound 3.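

In this assay the series now has its first readable one-place step: (aminomethyl)carbonyl in place of methyl on an amine nitrogen in a ring gives a 3.6-fold higher number from compound 1 to compound 3 (0.56 log units; beyond the scatter) and so moves towards weaker inhibition, beyond the usual scatter. This shows that the read-out responds to what sits on this ring nitrogen, and that a carbonyl-bearing group here does not by itself go with a lower number, while compound 2, which differs from compound 1 in more than one place, cannot be used to isolate the effect of its own carbonyl group. The data available offer no measured basis for explaining this step.

Going by these compounds, what stays open is which part of the (aminomethyl)carbonyl group goes with the higher number, the carbonyl or the terminal amine; a hydroxyacetyl group or a longer aminoalkyl carbonyl chain on the same nitrogen would help to separate the two. On these data alone, it is also open whether the same change would give a step of similar size on the core of compound 2.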